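The source may report more compounds than this note shows. Statements on the series, on what has been measured and on what is new or still open speak of the compounds shown alone.

In a functional assay on HT-29 cells (Homo sapiens) for inhibition, read by MTT assay, with a stated time of 48 h (a higher number here means a weaker inhibitor, a lower number a stronger inhibitor), compound 3 `COc1ccc(-c2cc(-c3cc(OC)c(OC)c(OC)c3)nc(-c3ccccc3)n2)c(OC)c1` gives only a limit, > 25000 nM. Compound 2 `COc1cc(-c2cc(-c3ccc(C)cc3)nc(-c3ccccc3)n2)cc(OC)c1OC` likewise gives only a limit, > 25000 nM. Compound 1 `COc1cc(-c2cc(-c3ccc(Cl)cc3)nc(-c3ccccc3)n2)cc(OC)c1OC` gives a number, 6230 nM. Compound 4 `COc1cc(-c2cc(-c3ccc(O)cc3)nc(-c3ccccc3)n2)cc(OC)c1OC` carries one change relative to compound 3: 4-hydroxyphenyl in place of 2,4-dimethoxyphenyl on an aromatic carbon. Within the data shown here, two measured steps bear on it. The first is an at least 4.0-fold higher number from compound 1 to compound 3 (0.60 log units; beyond the scatter), with 2,4-dimethoxyphenyl in place of 4-chlorophenyl. The second is an at least 4.0-fold higher number from compound 1 to compound 2 (0.60 log units; beyond the scatter), with methyl in place of chloro. Losing 2,4-dimethoxyphenyl reverses only part of the first step, and the second step warns that a new group in that position may not restore inhibition. The expected step in this assay is an at least 1.6-fold lower number from compound 3 to compound 4 (0.22 log units; that floor lies within the scatter), a modest shift towards stronger inhibition, with another limit still possible. Compound 4 is estimated at 15000 nM, with an expected range of 5000 nM to 40000 nM.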

Compound 4, half-maximal inhibitory concentration: 11300 nM
For compound 4 the middle estimate is 1.3-fold (0.12 log units) above the measured one; low and high end bracket the measured number.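

In this assay, the 4-hydroxyphenyl group restores a readable number at this position, so chloro is not the only substituent there that does: the change from 2,4-dimethoxyphenyl gives an at least 2.2-fold lower number from compound 3 to compound 4 (0.34 log units; beyond the scatter), and hydroxy in place of methyl gives an at least 2.2-fold lower number from compound 2 to compound 4 (0.34 log units; beyond the scatter). Hydroxy and chloro cannot be separated, with a 1.8-fold higher number from compound 1 to compound 4 (0.26 log units; within the scatter). Compound 2 and compound 3 stay limits rather than numbers: the limit of > 25000 nM in this assay, at which 2 of the 4 values shown sit.

Going by these compounds, whether an amine or a carboxylic acid in place of the hydroxy would give a stronger inhibitor than compound 1 and compound 4 remains open. On these data alone, the true values of compound 2 and compound 3 also remain open.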